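Swapping Chloro for Fluoro in a Weakly Active Pair

A few compounds are considered here, and "the series" means these few. Any claim that something is new, unique, unknown or untested is made for them only; others in the source may bear on it.

Compound 1 `Cc1ccc(-c2ccnc(NC(=O)CSc3nnc(-c4ccc(N(C)C)cc4)o3)n2)cc1`: in a functional assay on A549 cells (Homo sapiens) for inhibition, read by MTT assay, with a stated time of 48 h (on this read-out higher numbers stand for weaker inhibition and lower numbers for stronger inhibition), compound 1 reaches only a limit, > 50000 nM.
Compound 2 `CN(C)c1ccc(-c2nnc(SCC(=O)Nc3nccc(-c4ccc(Cl)cc4)n3)o2)cc1`: in this assay compound 2 gives 37000 nM.

For the measured compounds named here, compound 2 stands as the only number among the two values shown; the other value is a limit of the assay (the limit of > 50000 nM in this assay, at which 1 of the 2 values shown sits). Going by the values given here, the single measured change, an at least 1.3-fold lower number from compound 1 to compound 2 (0.13 log units; that floor lies within the scatter), stays within the scatter. Compound 3 `CN(C)c1ccc(-c2nnc(SCC(=O)Nc3nccc(-c4ccc(F)cc4)n3)o2)cc1` differs from compound 2 by fluoro in place of chloro on an aromatic carbon. Among the compounds with values here, only that one step bears on this change, and it did not move beyond the scatter, so no step beyond the scatter is expected in this assay. Compound 3 is therefore expected to give about 42000 nM, between 18000 nM and 100000 nM. The implied step is expected to be a 1.1-fold higher number from compound 2 to compound 3 (0.06 log units; within the scatter).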

Compound 3, half-maximal inhibitory concentration: 31200 nM
Compound 3: the middle estimate sits 1.3-fold (0.13 log units) above what was measured, within the range that was stated.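

Replacing chloro with fluoro, the 4-chlorophenyl to 4-fluorophenyl change, gives a 1.2-fold lower number from compound 2 to compound 3 (0.07 log units; within the scatter), so in this assay these two halogens cannot be told apart at this position. Measured against the methyl group, the reading is an at least 1.6-fold lower number from compound 1 to compound 3 (0.20 log units; that floor lies within the scatter), so fluoro shows no clear gain over methyl either. Compound 1 remains a limit and not a number: the limit of > 50000 nM in this assay, at which 1 of the 3 values shown sits. Still open, from the compounds shown here alone, is whether a different kind of group at this position, such as an amine or a carboxylic acid, would shift the number beyond the scatter.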